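Acetyl in place of hydroxyl hydrogen on a shared core

The compounds below may be only part of what the source reports. "The series", "measured", "known", "first", "only" and "open" are said of these compounds alone.

Compound 1 `NC(=O)c1c[nH]c([C@@H](O)c2ccccc2)cc1=O` gives > 50000 nM in a functional assay on K562 cells (Homo sapiens) for inhibition, read by sulforhodamine B assay, with a stated time of 48 h (a higher number here means a weaker inhibitor, a lower number a stronger inhibitor), a limit of the assay.
Compound 2 `COC(=O)c1c[nH]c([C@@H](O)c2ccccc2)cc1=O` gives > 50000 nM in this assay, a limit.
Compound 3 `NC(=O)c1cn(CCO)c([C@@H](O)c2ccccc2)cc1=O` gives > 50000 nM in this assay, a limit.

Compound 3 therefore stands at the same limit as the other two, and no order among them can be read. The two measured steps, a step that the two limits leave unreadable from compound 1 to compound 2 and a step that the two limits leave unreadable from compound 1 to compound 3, are likewise unreadable, since the limit of > 50000 nM in this assay, at which 3 of the 3 values shown sit, covers every value shown. Compound 4 `CC(=O)O[C@@H](c1ccccc1)c1cc(=O)c(C(N)=O)cn1CCO` differs from compound 3 by acetyl in place of hydrogen on an oxygen on a saturated carbon. Among the measured compounds shown here, no measured step touches this oxygen, so nothing in the data points in either direction. Given that all three neighbours sit at the limit, compound 4 is expected to remain there as well, with the step that the limit leaves unreadable from compound 3 to compound 4 estimated as no change beyond the scatter. Compound 4 is estimated at 80000 nM, within 20000 nM to 300000 nM.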

Compound 4, half-maximal inhibitory concentration: > 50000 nM
Compound 4 ended at the assay's limit (the forecaster's own chance of this, stated with the estimate: 85%); the middle value lies beyond the limit too.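

No new step can be read between compound 3 and compound 4, since both stand at the same limit: the limit of > 50000 nM in this assay, at which 4 of the 4 values shown sit. The compounds shown leave open how strongly any of the four inhibits in this assay and whether any of these changes matters there.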